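This account rests on a few compounds, and the source may have more. Where it says the series, first, only, none or still open, it means among the compounds named here.

Of the compounds shown here, three have so far been tested in an ADME assay on WI-38 cells (Homo sapiens) for cytotoxicity, read by MTT assay, with a stated time of 48 h; a lower number here means a stronger inhibitor, a higher number a weaker inhibitor. Compound 1 `CC(C)(Oc1ccc(Cl)cc1)C(=O)Oc1ccc(C(N)=S)cc1` reaches only the limit > 800000 nM, which is a bound of the assay and not a number. Compound 2 `CC(C)(Oc1ccc(Cl)cc1)C(=O)NCCOC(=S)Nc1ccc([N+](=O)[O-])cc1Cl` likewise gives only the limit > 800000 nM. Compound 3 `O=C(NCCOC(=S)Nc1ccccc1)c1cccnc1` also stops at the limit > 800000 nM. All three values therefore sit at the limit of > 800000 nM in this assay, at which 3 of the 3 values shown sit, and compound 3 stands at that same limit, indistinguishable from the other two. Compound 4 `COc1ccc(NC(=S)OCCNC(=O)c2cccnc2)cc1` differs from compound 3 by methoxy in place of hydrogen on an aromatic carbon. Going by the values given here, no pair of measured compounds separated by a single change exists here, so no size of step can be read off. The step is expected to be a number no higher from compound 3 to compound 4 (the limit leaves the size open), nothing beyond scatter. Compound 4 is therefore estimated at 800000 nM, with a range from 400000 nM to 1600000 nM.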

Compound 4, half-maximal inhibitory concentration: 781000 nM
Compound 4: the middle estimate sits 1.0-fold (0.01 log units) above what was measured, within the range that was stated.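

Methoxy in place of hydrogen on an aromatic carbon, para to a large group, is the one change here that brings a measured number rather than a limit in this assay. The change gives an at least 1.0-fold lower number from compound 3 to compound 4 (0.01 log units; that floor lies within the scatter) and so shows no shift beyond the scatter. That step is only a floor, because its starting point is a limit: the limit of > 800000 nM in this assay, at which 3 of the 4 values shown sit.

On these data alone, whether an amine, a carboxylic acid or a longer chain such as ethoxy on the same aromatic carbon would shift the number beyond the scatter stays open.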